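Alkyl size on the amide nitrogen; isopropyl to butyl

The compounds below may be only part of what the source reports. "The series", "measured", "known", "first", "only" and "open" are said of these compounds alone.

Compound 3 `CCC1C(=O)N(C)c2cnc(-n3ccc4cc(C(=O)NC(C)C)ccc43)nc2N1c1ccn(C)n1` gives 8910 nM in a functional assay on K562 cells (Homo sapiens) for antiproliferative activity, read by CCK-8 assay, with a stated time of 72 h (on this read-out higher numbers stand for weaker inhibition of growth and lower numbers for stronger inhibition of growth), the second highest of the three numbers measured. Compound 1 `CCC1C(=O)N(C)c2cnc(-n3ccc4cc(C(N)=O)ccc43)nc2N1c1ccn(C)n1` gives 31300 nM and compound 2 `CCC1C(=O)N(C)c2cnc(-n3ccc4cc(C(=O)NCC(C)C)ccc43)nc2N1c1ccn(C)n1` gives 5600 nM. The steps of a 5.6-fold lower number from compound 1 to compound 2 (0.75 log units; beyond the scatter) and a 3.5-fold lower number from compound 1 to compound 3 (0.55 log units; beyond the scatter) show that an alkyl group on the amide-type nitrogen lowers the number modestly, while a 1.6-fold higher number from compound 2 to compound 3 (0.20 log units; within the scatter) shows isopropyl and isobutyl cannot be separated. Compound 4 `CCCCNC(=O)c1ccc2c(ccn2-c2ncc3c(n2)N(c2ccn(C)n2)C(CC)C(=O)N3C)c1` differs from compound 3 by butyl in place of isopropyl on an amide-type nitrogen. Among the measured compounds shown here, the only comparison among alkyl groups here is isopropyl against isobutyl. The step of a 1.4-fold lower number from compound 3 to compound 4 (0.14 log units; within the scatter) is therefore expected to stay within the scatter, because a 1.6-fold higher number from compound 2 to compound 3 (0.20 log units; within the scatter) lies within it. Compound 4 is estimated at 6500 nM, in the range 3000 nM to 14000 nM.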

Compound 4, concentration for 50% growth inhibition: 14100 nM
Compound 4: the middle estimate sits 2.2-fold (0.34 log units) below what was measured, outside the stated range (above it).
By their numbers in this assay, from the lowest: compounds 2, 3 and 4 (each within the scatter of the next, the first and the last beyond it); then compound 1.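

Butyl cannot be separated from isopropyl on the amide-type nitrogen, with a 1.6-fold higher number from compound 3 to compound 4 (0.20 log units; within the scatter) in this comparison. Butyl and isobutyl do separate, with a 2.5-fold higher number from compound 2 to compound 4 (0.40 log units; beyond the scatter) as the first step between two alkyl groups here to lie beyond the scatter, so the shape of the alkyl group counts as well as its presence. Butyl still gives a lower number than the amide hydrogen, with a 2.2-fold lower number from compound 1 to compound 4 (0.35 log units; beyond the scatter) on that change.

From the compounds shown here alone, whether a longer chain such as hexyl, a cyclohexyl ring or a terminal amine would give a number lower than that of compound 2 remains open. No measurement at hand accounts for the difference between butyl and isobutyl.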